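This account rests on a few compounds, and the source may have more. Where it says the series, first, only, none or still open, it means among the compounds named here.

Compound 1 `Cc1ccncc1-c1ccc2[nH]c(=O)nc(-c3ccccc3)c2c1` was tested in an ADME assay on THP-1 cells (Homo sapiens) for cytotoxicity, read by MTT assay, with a stated time of 72 h; a lower number here means that less compound is needed, a higher number that more compound is needed for the effect. In this assay compound 1 gives > 50000 nM, which is a limit of the assay rather than a measured number. A related structure, compound 2 `O=c1nc(-c2ccccc2)c2cc(-c3cc[nH]n3)ccc2[nH]1`, was tested in the same way. In this assay compound 2 gives > 50000 nM, again a limit and not a number. The step that the two limits leave unreadable from compound 1 to compound 2 cannot be read because both values sit at the same limit (the limit of > 50000 nM in this assay, at which 2 of the 2 values shown sit); it is not known whether the two compounds differ at all.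

Compound 3 `CN1CCN(c2ccc3[nH]c(=O)nc(-c4ccccc4)c3c2)CC1` differs from compound 1 in one place: 4-methylpiperazin-1-yl in place of 4-methylpyridin-3-yl on an aromatic carbon. Going by the values given here, no measured step bears on this change directly, and the one step that exists is unreadable. The expectation for compound 3 therefore rests only on the fact that both measured compounds stayed at the limit of this assay. The expected step of a number no higher from compound 1 to compound 3 (the limit leaves the size open) is none beyond the scatter, and a result that is once more a limit seems most likely. For compound 3 the estimated value in this assay is 50000 nM, with a range from 15000 nM to 100000 nM.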

Compound 3, half-maximal effective concentration: > 50000 nM
Compound 3 ended at the assay's limit; the forecaster's own chance of this, stated with the estimate: 75%; the middle value lies on the limit itself.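

Compound 3 also gives a limit rather than a number, so the steps linking compound 1, compound 2 and compound 3 cannot be read, because all three values sit at the same limit: the limit of > 50000 nM in this assay, at which 3 of the 3 values shown sit.

The compounds shown leave open whether 4-methylpyridin-3-yl, 1H-pyrazol-3-yl and 4-methylpiperazin-1-yl differ at all in this assay.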